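Chain Lengthening on an Alkyne Side Arm and Cytotoxicity

The compounds below may be only part of what the source reports. "The series", "measured", "known", "first", "only" and "open" are said of these compounds alone.

Compound 1 `CCCCC#Cc1cc2cn(C)c(=O)nc2o1` and compound 2 `CCCCCCC#Cc1cc2cn(C)c(=O)nc2o1` share a core that carries a triple bond followed by a saturated chain. In a functional assay on HEL cells (Homo sapiens) for cytotoxicity (on this read-out lower numbers stand for higher toxicity in this test and higher numbers for lower toxicity in this test), compound 1 reaches only a limit of the test, >= 217000 nM; this is the limit of >= 217000 nM in this assay, at which 1 of the 2 values shown sits. In this assay, going by the values given here, compound 2 gives 194000 nM, the only full number between the two. The step of an at least 1.1-fold lower number from compound 1 to compound 2 (0.04 log units; that floor lies within the scatter) came with ethyl in place of hydrogen on a saturated chain carbon, four bonds along the chain from a triple-bonded carbon. Compound 3 `CCCCCCCCC#Cc1cc2cn(C)c(=O)nc2o1` carries the same kind of change once more: ethyl in place of hydrogen on a saturated chain carbon, six bonds along the chain from a triple-bonded carbon. Among the compounds with values here, the only step that bears on this is the one from compound 1 to compound 2, and it sat within the scatter, so for this assay no step beyond the scatter is expected. Compound 3 is therefore estimated at 160000 nM, within a range from 70000 nM to 300000 nM, which means an expected step of a 1.2-fold lower number from compound 2 to compound 3 (0.08 log units; within the scatter).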

Compound 3, minimum cytotoxic concentration: > 175000 nM
Compound 3: only a limit was reported; the forecaster's own chance of this, stated with the estimate: 30%; middle value at least 1.0-fold (0.03 log units) away from the limit.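

In this assay compound 3 gives > 175000 nM, which is a limit of the test and not a full number. Its steps from compound 1 and from compound 2 cannot be read. The compounds shown leave open whether the longer chain of compound 3 changes cytotoxicity at all.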